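The compounds below may be only part of what the source reports. "The series", "measured", "known", "first", "only" and "open" are said of these compounds alone.

Compound 1 `CCCn1c(=O)c2nc(-n3cccn3)[nH]c2n(CCC)c1=O` in an in vitro assay on HEK293 cells for displacement of a labelled ligand from adenosine receptor A2b (Homo sapiens); a lower number here means a stronger inhibitor, a higher number a weaker inhibitor: > 5800 nM, a limit.
Compound 2 `CCCn1c(=O)c2nc(-c3cnn(Cc4ccccc4C(F)(F)F)c3)[nH]c2n(CCC)c1=O` in this assay: 37 nM.
Compound 3 `CCCn1c(=O)c2nc(-c3cnn(-c4ccc(Cl)cc4)c3C(F)(F)F)[nH]c2n(CCC)c1=O` in this assay: > 6600 nM, a limit.

Of the three values shown, only compound 2 has a measured inhibition constant. Compound 1 reaches only a limit, (the limit of > 5800 nM in this assay, at which 1 of the 3 values shown sits). Compound 3 likewise reaches only a limit, (the limit of > 6600 nM in this assay, at which 1 of the 3 values shown sits). Compound 2 is thus the single firm point from which to move.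

Compound 4 `CCCn1c(=O)c2nc(-c3cnn(Cc4ccc(F)c(C(F)(F)F)c4)c3)[nH]c2n(CCC)c1=O` has not yet been measured. It differs from compound 2 in one place: 4-fluoro-3-(trifluoromethyl)phenyl in place of 2-(trifluoromethyl)phenyl on a saturated chain carbon bound to an aromatic nitrogen. The shared core and the saturated chain carbon bound to an aromatic nitrogen stay the same; only the aryl group on that carbon changes. No measured pair among the shown compounds makes a change of this kind, so there is no step to lean on. The expectation is a step of modest size, within or just beyond the scatter, with no clear direction. Compound 4 is therefore estimated at 55 nM in this assay, with a range from 12 nM to 250 nM. That estimate corresponds to an expected step of a 1.5-fold higher number from compound 2 to compound 4 (0.17 log units; within the scatter).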

Compound 4, inhibition constant: 640 nM
The estimate for compound 4 lay 12-fold (1.07 log units) below the measured number; measured number above the stated range.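

For the compounds shown here, this is the first measured step on the aryl group held by the saturated chain carbon bound to an aromatic nitrogen. In this assay replacing 2-(trifluoromethyl)phenyl with 4-fluoro-3-(trifluoromethyl)phenyl gives a 17-fold higher number from compound 2 to compound 4 (1.24 log units; beyond the scatter) and so shows that binding here is sensitive to the substitution on this ring, even though the ring type stays the same and neither group has hydrogen-bond donors or acceptors. The data shown offer no measurement that accounts for the size of this step.

Compound 4 differs from compound 2 both in the added fluorine and in where the trifluoromethyl group sits, and the compounds shown do not separate these two changes. Also open, as far as these compounds go, is how a plain phenyl, or a phenyl carrying a nitrile or a methoxy group instead of trifluoromethyl, would behave on this carbon.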